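The source may report more compounds than this note shows. Statements on the series, on what has been measured and on what is new or still open speak of the compounds shown alone.

Compound 1, `ClCc1ccccc1Cn1cnc2c(Cl)nc(Cl)nc21`, gives 210 nM in a functional assay on OVCAR-3 cells (Homo sapiens) for cytotoxicity, read by sulforhodamine B assay, with a stated time of 48 h; a higher number here means a weaker inhibitor of growth, a lower number a stronger inhibitor of growth. Compound 2, `ClCc1cccc(Cn2cnc3ncnc(Cl)c32)c1`, gives 1770 nM in this assay. Compound 3, `ClCc1ccc(Cn2cnc3c(Cl)nc(Cl)nc32)cc1`, gives 2000 nM in this assay.

Of these three, compound 1 has the lowest number in this assay and is therefore the strongest inhibitor of growth among them; the numbers for compound 2 and compound 3 both lie beyond the scatter above it, so the difference is real and not noise. All three share the same two-ring core and carry a chloromethyl-bearing benzyl group on it, differing in where the chloromethyl sits on the benzyl ring and in how many chloro groups the core carries.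

Compound 4, `Nc1nc(Cl)c2ncn(Cc3ccccc3CCl)c2n1`, has not yet been tested in this assay. It differs from compound 1 in one spot only: amino in place of chloro on an aromatic carbon. For the measured compounds named here, no measured pair in this set makes this same exchange, so there is nothing here to show its direction or size directly. The expectation is a modest weakening, with the step in this assay estimated at a 2.4-fold higher number from compound 1 to compound 4 (0.38 log units; beyond the scatter), which would still leave compound 4 well ahead of compound 2 and compound 3. Compound 4 is thus expected to give about 500 nM in this assay, with a likely range from 150 nM to 2000 nM.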

Compound 4, concentration for 50% growth inhibition: 3390 nM
The estimate for compound 4 lay 6.8-fold (0.83 log units) below the measured number; the measured number lies above the stated range.
By their numbers in this assay, from the lowest: compound 1; then compounds 2, 3 and 4 (each within the scatter of the next).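

In this assay, replacing chloro with amino on the aromatic carbon between two ring nitrogen atoms comes with a 16-fold higher number from compound 1 to compound 4 (1.21 log units; beyond the scatter), so growth inhibition in this pair is clearly sensitive to what sits at this position. For the compounds shown here, this is the first step here in which only one place changes, so the loss can be tied to a single exchange rather than to a mix of chloromethyl placement and chloro count. The exchange is small by count, with one heavy atom leaving and one entering, no net charge on either group, and a hydrogen-bond donor and acceptor arriving with the amino, but nothing available explains why the step is this large.

A single pair cannot show whether chloro itself is what matters here or whether other groups at this carbon, such as fluoro, methyl or methoxy, would keep the number of compound 1. It also leaves open whether the same exchange would produce a step of similar size with the chloromethyl group elsewhere on the benzyl ring.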